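The source may hold more compounds than are shown below. What is called first, only, known or untested is meant among the compounds shown, and "the series" means these compounds.

Measured in an ADME assay on RAW264.7 cells (Mus musculus) for cytotoxicity, read by MTT assay, with a stated time of 24 h, in the presence of a further agent that is not named here; on this read-out higher numbers stand for weaker inhibition and lower numbers for stronger inhibition:
Compound 1 `O=C1OC(Cc2nc(-c3ccc(-c4ccccc4)cc3)no2)c2ccccc21` gives > 40000 nM
Compound 2 `COc1ccc(C(O)C2OC(=O)c3c(OC)cc(OC)cc32)cc1` gives > 40000 nM

Compound 2 stands at > 40000 nM as a limit of the assay and not a number. The record so far is the limit of > 40000 nM in this assay, at which 2 of the 2 values shown sit, and holds no exact number. Compound 3 `COCCCOc1ccc(C(O)C2OC(=O)c3c(OC)cc(OC)cc32)cc1` follows from compound 2 by one change, 2-methoxyethyl in place of hydrogen on a saturated chain carbon bound to an oxygen on an aromatic ring turning methoxy into 3-methoxypropoxy. In this assay no step beyond the scatter is expected, and the estimated step is a step that the limit leaves unreadable from compound 2 to compound 3 with no clear direction. This expectation rests on compound 2 at > 40000 nM as a limit. For compound 3 the estimated value is 45000 nM with an expected range from 20000 nM to 100000 nM in this assay.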

Compound 3, half-maximal inhibitory concentration: > 40000 nM
Compound 3 gave a limit, no number (the forecaster's own chance of this, stated with the estimate: 85%); the middle value does not contradict the limit.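

Compound 3 gives [ > 40000 nM ], a limit and not a number. Compound 2 also stands at a limit, so no step can be read from compound 2 to compound 3. The compounds shown leave open whether methoxy and 3-methoxypropoxy differ at all.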